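This account rests on a few compounds, and the source may have more. Where it says the series, first, only, none or still open, it means among the compounds named here.

Within the data shown here, in a functional assay on a cell-free system (plasma) for agonist activity at thromboxane A2 receptor (Homo sapiens) (on this read-out higher numbers stand for weaker inhibition and lower numbers for stronger inhibition), compound 2 `O=C(O)COC/C=C1/C[C@H]2C[C@@H](O)[C@H](/C=N/NC(=O)Nc3ccccc3)[C@H]2C1` gives 1400 nM, the highest of the two numbers measured so far. Among the measured compounds shown here, its nearest neighbour is compound 1 `O=C(O)COC/C=C1/C[C@H]2C[C@@H](O)[C@H](/C=N/NC(=O)Nc3cccc(Cl)c3)[C@H]2C1`, which in this assay gives 180 nM; the single step between them, a 7.8-fold higher number from compound 1 to compound 2 (0.89 log units; beyond the scatter), comes from hydrogen in place of chloro on an aromatic carbon. Compound 3 `O=C(O)COC/C=C1/C[C@H]2C[C@@H](O)[C@H](/C=N/NC(=O)Nc3ccc(Cl)c(Cl)c3)[C@H]2C1` is not yet measured. The change from compound 2 to compound 3 is 3,4-dichlorophenyl in place of phenyl on an amide-type nitrogen. For the measured compounds named here, only one measured step bears on it, a 7.8-fold higher number from compound 1 to compound 2 (0.89 log units; beyond the scatter), and that step runs the other way: removing one chloro raised the number modestly. Going from compound 2 to compound 3 adds two chloro groups, so a fall in the number at least as large as that single-chloro step is expected, with the estimated step being a 12-fold lower number from compound 2 to compound 3 (1.07 log units; beyond the scatter). Compound 3 is therefore expected to give about 120 nM in this assay, within a range from 40 nM to 400 nM.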

Compound 3, half-maximal inhibitory concentration: 60 nM
Estimate against measurement, compound 3: 2.0-fold (0.30 log units) above, and the stated range covers the measured number.
By their numbers in this assay, from the lowest: compound 3; then compound 1; then compound 2.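

In this assay the ring on the amide-type nitrogen takes a second chloro with further gain: the full change to 3,4-dichlorophenyl gives a 23-fold lower number from compound 2 to compound 3 (1.37 log units; beyond the scatter) and adding one more chloro to the ring of compound 1 still gives a 3.0-fold lower number from compound 1 to compound 3 (0.48 log units; beyond the scatter) here too. Across these three compounds the number falls with each added chloro, and none goes against this, so the effect of the first chloro does not stop at one group. Nothing shown gives a reason for this fall.

Open, on these data alone, is whether chloro itself matters, since a methyl, methoxy or trifluoromethyl group on the same ring could read differently. Also open, as far as these compounds go, is how a phenyl ring carrying only one chloro at the other printed place of the 3,4-dichlorophenyl group would compare.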